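Adding a Methyl to the Fastest-Cleared Compound

A few compounds are considered here, and "the series" means these few. Any claim that something is new, unique, unknown or untested is made for them only; others in the source may bear on it.

Compound 1 `C[C@]1(O)C[C@](c2ccnc(C(F)(F)F)c2)([C@H](O)c2ccccn2)C1`: 83.3 mL/min/kg
Compound 2 `O[C@H](c1ccccn1)[C@]1(c2ccnc(C(F)(F)F)c2)C[C@H](O)C1`: 50 mL/min/kg
Compound 3 `O[C@H](c1ccccn1)[C@]1(c2ccnc(C(F)(F)F)c2)C[C@@H](O)C1`: 200 mL/min/kg

In an ADME assay on liver for metabolic stability, with Liver microsome (Rattus norvegicus) as the target, read by LC-MS, using microsomes, with a stated time of 5 h (on this read-out lower numbers stand for slow clearance and higher numbers for fast clearance), compound 3 gives 200 mL/min/kg, the highest of the three numbers. The next compound, compound 4 `C[C@]1(O)C[C@@](c2ccnc(C(F)(F)F)c2)([C@H](O)c2ccccn2)C1`, keeps the drawn configuration of compound 3 and changes one group: methyl in place of hydrogen on a saturated ring carbon. Within the data shown here, two measured steps bear on this. The nearest parallel is a 1.7-fold lower number from compound 1 to compound 2 (0.22 log units; within the scatter), the same swap in reverse, but in the other drawn configuration. Read backwards, it suggests that adding methyl need not move the number beyond the scatter. The second step, a 4.0-fold higher number from compound 2 to compound 3 (0.60 log units; beyond the scatter), comes with the fact that compounds 2 and 3 differ only in the configuration as drawn, so configuration can matter and the parallel may not carry over fully. No step beyond the scatter is therefore expected, with a slight lean downward since compound 1, which also carries the methyl, sits lower. The expected change is a 1.3-fold lower number from compound 3 to compound 4 (0.10 log units; within the scatter). The estimate for compound 4 is 160 mL/min/kg, with an expected range from 70 mL/min/kg to 350 mL/min/kg.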

Compound 4, clearance: 50 mL/min/kg
Estimate against measurement, compound 4: 3.2-fold (0.51 log units) above; measured number outside the range, below it.
By their numbers in this assay, from the lowest: compounds 2, 4 and 1 (each within the scatter of the next); then compound 3.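

In this assay, methyl in place of hydrogen on a saturated ring carbon gives a 4.0-fold lower number from compound 3 to compound 4 (0.60 log units; beyond the scatter) and so moves the number beyond the scatter, which the same swap in the other drawn configuration did not do: the same change on two cores in this assay, a 1.7-fold lower number (0.22 log units; within the scatter) from compound 1 to compound 2 and a 4.0-fold higher number (0.60 log units; beyond the scatter) from compound 4 to compound 3, 6.7-fold (0.82 log units) apart, beyond the scatter of two such steps. With the methyl present, the drawn configuration gives only a 1.7-fold lower number from compound 1 to compound 4 (0.22 log units; within the scatter) whereas without the methyl it gives a 4.0-fold higher number from compound 2 to compound 3 (0.60 log units; beyond the scatter) and so configuration separates the hydrogen pair but not the methyl pair. The effect of this change at this position therefore depends on the drawn configuration, within these four compounds.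

Why the two configurations respond differently stays open. So does whether an ethyl group or an amine on the same ring carbon would show the same dependence on configuration.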